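This account rests on a few compounds, and the source may have more. Where it says the series, first, only, none or still open, it means among the compounds named here.

Compound 2 `Cc1c(F)c(Oc2cccc(C(=N)N)c2)nc(Oc2cccc(C(=O)N3CCCC3)c2)c1F` gives 2800 nM in an assay on isolated protein for inhibition of serine protease 1 (Bos taurus); a higher number here means a weaker inhibitor, a lower number a stronger inhibitor. Among the compounds with values here, only two plain numbers stand in this assay; the other belongs to compound 3 `Cc1c(F)c(Oc2cccc(C(=N)N)c2)nc(Oc2cccc(-n3ccnc3)c2)c1F`, which gives 4800 nM, and the gap a 1.7-fold higher number from compound 2 to compound 3 (0.23 log units; within the scatter) separates them. Compound 1 `Cc1c(F)c(Oc2cccc(C(=N)N)c2)nc(Oc2cccc([N+](=O)[O-])c2)c1F` reaches only a limit of the assay, > 5000 nM. The step of an at least 1.7-fold lower number from compound 1 to compound 2 (0.25 log units; that floor lies within the scatter) rests on that limit (the limit of > 5000 nM in this assay, at which 1 of the 3 values shown sits). Compound 4 `Cc1c(F)c(Oc2cccc(CC(N)=O)c2)nc(Oc2cccc(C(=N)N)c2)c1F` differs from compound 2 at the same position touched by those two steps: carbamoylmethyl in place of (pyrrolidin-1-yl)carbonyl on an aromatic carbon. Both measured steps at this position stayed within the scatter, so no shift beyond the scatter is expected here either. The expected step is a 1.3-fold higher number from compound 2 to compound 4 (0.10 log units; within the scatter). Compound 4 is expected to give about 3500 nM in this assay, with a range from 1200 nM to 10000 nM.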

Compound 4, inhibition constant: > 5000 nM
Compound 4 ended at the assay's limit; the forecaster's own chance of this, stated with the estimate: 25%; at least 1.4-fold (0.15 log units) between middle value and limit.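

Compound 4 stands at a limit of this assay and not at a number, as compound 1 does: the limit of > 5000 nM in this assay, at which 2 of the 4 values shown sit. Carbamoylmethyl, which has no ring and carries a hydrogen-bond donor, therefore adds no new readable number at this position, and its two readable steps are only floors: an at least 1.7-fold higher number from compound 2 to compound 4 (0.25 log units; that floor lies within the scatter) and an at least 1.0-fold higher number from compound 3 to compound 4 (0.01 log units; that floor lies within the scatter). The step between the two compounds at the limit cannot be read. From the compounds shown here alone, whether an amine or a carboxylic acid on this aromatic carbon would shift the number beyond the scatter stays open.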